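Ortho-substituted azole series: imidazole variant of compound 3

This account rests on a few compounds, and the source may have more. Where it says the series, first, only, none or still open, it means among the compounds named here.

Measured compounds:
compound 1 `Cc1n[nH]c(-c2ccccc2NCC2=NCCN2)n1` 794 nM
compound 2 `Cn1ncnc1-c1ccccc1NCC1=NCCN1` 2 nM
compound 3 `Cn1cccc1-c1ccccc1NCC1=NCCN1` 20 nM

All values come from an in vitro functional assay on cells (Fibroblast) for agonist activity at Alpha-1A adrenergic receptor (Homo sapiens); on this read-out lower numbers stand for an effect already at smaller amounts and higher numbers for an effect only at larger amounts of compound. Compound 3 stands second highest of the three: compound 2 is nearest, with a 10-fold higher number from compound 2 to compound 3 (1.00 log units; beyond the scatter), and compound 1 furthest, with a 40-fold lower number from compound 1 to compound 3 (1.60 log units; beyond the scatter).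

Compound 4 `Cn1ccnc1-c1ccccc1NCC1=NCCN1` is not yet measured. Its change from compound 3 is 1-methyl-1H-imidazol-2-yl in place of 1-methyl-1H-pyrrol-2-yl on an aromatic carbon. Going by the values given here, the steps that bear on it are a 10-fold higher number from compound 2 to compound 3 (1.00 log units; beyond the scatter) and a 400-fold lower number from compound 1 to compound 2 (2.60 log units; beyond the scatter), both large, showing that the azole attached to the shared core governs this read-out strongly. Since compound 4 carries a ring with more hetero atoms than compound 3 but fewer than compound 2, a lower number than compound 3 is expected, of a size between those steps: a 4.0-fold lower number from compound 3 to compound 4 (0.60 log units; beyond the scatter). Compound 4 is thus estimated at 5 nM, range 1.5 nM to 16 nM.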

Compound 4, half-maximal effective concentration: 6.31 nM
Compound 4: the middle estimate sits 1.3-fold (0.10 log units) below what was measured; measured number inside the range.
By their numbers in this assay, from the lowest: compound 2; then compound 4; then compound 3; then compound 1.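

In this assay, the 1-methyl-1H-imidazol-2-yl ring shows a graded response at this position, with a 3.2-fold lower number from compound 3 to compound 4 (0.50 log units; beyond the scatter) and a 3.2-fold higher number from compound 2 to compound 4 (0.50 log units; beyond the scatter) placing compound 4 on a scale where the number falls as hetero atoms are added across compound 3, compound 4 and compound 2. Compound 1 goes against this scale (with a 130-fold lower number from compound 1 to compound 4 (2.10 log units; beyond the scatter)), so the hetero atom count alone does not order the series. Nothing at hand accounts for these steps.

Open, going by these compounds, is whether the scale holds for a 1-ethyl group in place of the 1-methyl group. Also open, on these data alone, is how a carboxylic acid or an amine on the five-membered ring would read.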